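Adding a Sulfamoylmethyl Group to Compound 3

A few compounds are considered here, and "the series" means these few. Any claim that something is new, unique, unknown or untested is made for them only; others in the source may bear on it.

Compound 1, `CC(C)(C)c1ccc2nc(N)sc2c1`: 4 mg/kg
Compound 2, `Nc1nc2ccc(C(=O)C(F)(F)F)cc2s1`: > 10 mg/kg (a limit of the assay, not a number)
Compound 3, `Cn1c(=N)sc2cc(OC(F)(F)F)ccc21`: 5 mg/kg

In a functional assay on the whole organism with Rattus norvegicus as the target (a higher number here means that more compound is needed for the effect, a lower number that less compound is needed), compound 1 gives 4 mg/kg. In this assay compound 3 gives 5 mg/kg, and these two numbers lie within the usual scatter of each other, so neither can be called stronger or weaker. For compound 2 this assay reports only > 10 mg/kg, which is a limit rather than a number; (the limit of > 10 mg/kg in this assay, at which 1 of the 3 values shown sits).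

Compound 4, `N=c1sc2cc(OC(F)(F)F)ccc2n1CCS(N)(=O)=O`, has not yet been measured in this assay. It differs from compound 3 by a single change: sulfamoylmethyl in place of hydrogen on a saturated chain carbon bound to an aromatic nitrogen. Among the compounds with values here, no two measured compounds here differ in just one place, so there is no measured step to lean on for the size or direction of this change.

With nothing in the measured compounds pointing either way, the step from compound 3 to compound 4 is expected to be small, a 1.2-fold higher number from compound 3 to compound 4 (0.08 log units; within the scatter), not beyond the usual scatter. In this assay compound 4 is estimated at 6 mg/kg, within a range from 2.5 mg/kg to 15 mg/kg.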

Compound 4, dose for half-maximal effect: 6 mg/kg
Beside the measured number, compound 4's estimate shows no gap at the digits printed; low and high end bracket the measured number.
By their numbers in this assay, from the lowest: compounds 1, 3 and 4 (each within the scatter of the next). At a limit, above all of these: compound 2.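

In this assay, the first step measured at this place reads a 1.2-fold higher number from compound 3 to compound 4 (0.08 log units; within the scatter). On a saturated chain carbon bound to an aromatic nitrogen, sulfamoylmethyl can thus stand in place of hydrogen, turning methyl into 2-sulfamoylethyl, with no difference that can be told from the scatter of repeated measurements. Adding this group of several heavy atoms therefore leaves the dose needed in the whole animal indistinguishable from that of the smaller methyl compound, and nothing shown here gives a reason for this flat result.

Going by these compounds, it remains open whether a plain ethyl chain, without the sulfamoyl end, would give a similar number, so the chain and its end cannot yet be read apart. Also open, on these data alone, is how a longer chain ending in an amine or a carboxylic acid would fare at this place.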